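Replacing the Acid-Bearing Group on Compound 1

The compounds below may be only part of what the source reports. "The series", "measured", "known", "first", "only" and "open" are said of these compounds alone.

Measured compounds:
compound 1, `CC(C)c1onc(-c2c(Cl)cccc2Cl)c1COc1ccc(N(C)C(=O)c2cccc(C(=O)O)c2)c(C(F)(F)F)n1`, gives 35%
compound 2, `Cc1cc(OCc2c(-c3c(Cl)cccc3Cl)noc2C(C)C)ncc1[N+](=O)[O-]`, gives 58%
compound 3, `Cc1cc(OCc2c(-c3c(Cl)cccc3Cl)noc2C(C)C)nc2ccccc12`, gives 40%

All three values come from a functional assay on HEK293 cells for agonist activity at Bile acid receptor (Homo sapiens); on this read-out lower numbers stand for smaller maximal responses and higher numbers for larger maximal responses. Among the three, compound 1 has the lowest number. The nearest to it is compound 3, whose value lies within the usual scatter of compound 1, so the two cannot be told apart. The furthest is compound 2, whose value lies beyond the scatter, a clear gap.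

Compound 4, `CC(C)c1onc(-c2c(Cl)cccc2Cl)c1COc1ccc(N(C)Cc2ccc(OCCO)cc2)c(C(F)(F)F)n1`, has not yet been measured. It differs from compound 1 in one place: 4-(2-hydroxyethoxy)benzyl in place of (3-carboxyphenyl)carbonyl on a nitrogen on an aromatic ring. The group that leaves carries the carbonyl and the carboxylic acid; the group that enters carries the hydroxyethoxy chain on a benzyl ring. Within the data shown here, no pair among the measured compounds shows a change of this kind, so there is no measured step to lean on.

Given that, the expected step in this assay from compound 1 to compound 4 is a number 10 percentage points higher from compound 1 to compound 4 (within the scatter), a modest rise that may well stay within the scatter. For compound 4 the estimated maximal response is 45%, with a range from 20% to 75%.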

Compound 4, largest response reached (reported as efficacy), in percent of the reference or control that the assay uses: 43%
Compound 4: the middle estimate sits 2 percentage points above what was measured; the range from low to high includes it.
By their numbers in this assay, from the lowest: compounds 1, 3 and 4 (each within the scatter of the next); then compound 2.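

In this assay, putting 4-(2-hydroxyethoxy)benzyl in place of (3-carboxyphenyl)carbonyl on this nitrogen gives a number 8 percentage points higher from compound 1 to compound 4 (within the scatter) and so the two compounds cannot be told apart on this read-out. Among these compounds, this is the first change seen at this place on its own: the carbonyl and the carboxylic acid both leave, while the six-membered aromatic ring and the heavy-atom count stay the same, so in this pair neither the carbonyl nor the carboxylic acid is needed to keep a maximal response of this size. No measurement shown speaks to why the two groups give matching responses.

Both groups leave at once, so this pair cannot separate the part played by the carbonyl from that of the carboxylic acid; a benzyl ring carrying a carboxylic acid, or a carbonyl-linked ring carrying the hydroxyethoxy chain, would be needed to pull them apart. The compounds shown also leave open how an amine in place of the hydroxyl, or a longer chain in place of the hydroxyethoxy, would read in this assay at this nitrogen.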